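From Trifluoromethoxy to Fluoro: An Expected Small Step

The compounds below may be only part of what the source reports. "The series", "measured", "known", "first", "only" and "open" are said of these compounds alone.

compound 1 `COc1nc2ccc(Br)cc2cc1C(c1ccccc1)n1cc(-c2ccc(Br)cc2)nn1`: 6.92%
compound 2 `CCCc1cn(C(c2ccccc2)c2cc3cc(Br)ccc3nc2OC)nn1`: -2.25%
compound 3 `COc1nc2ccc(Br)cc2cc1C(c1ccccc1)n1cc(-c2ccc(OC(F)(F)F)cc2)nn1`: -2.24%

In an ADME assay on HeLa cells (Homo sapiens) for cytotoxicity, read by sulforhodamine B assay, with a stated time of 48 h, tested at 10 uM (on this read-out higher numbers stand for more inhibition at the one concentration tested (going by the name of the read-out) and lower numbers for less inhibition), compound 1 gives 6.92%, compound 2 gives -2.25% and compound 3 gives -2.24%. Compound 3 holds the second highest of the three numbers. Its nearest neighbour is compound 2, with a number 0 percentage points higher from compound 2 to compound 3 (within the scatter). Its furthest is compound 1, with a number 9.2 percentage points lower from compound 1 to compound 3 (within the scatter). All three numbers thus sit within the scatter of one another, and none of the numbers can be called higher or lower than the others.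

Compound 4 `COc1nc2ccc(Br)cc2cc1C(c1ccccc1)n1cc(-c2ccc(F)cc2)nn1` is not yet measured. It differs from compound 3 in one place: fluoro in place of trifluoromethoxy on an aromatic carbon.

Among the measured compounds shown here, two measured steps bear on this. The step at the same place, a number 9.2 percentage points lower from compound 1 to compound 3 (within the scatter), exchanged one group on that aromatic carbon for another and stayed within the scatter. The step of a number 0 percentage points higher from compound 2 to compound 3 (within the scatter) exchanged the whole 4-(trifluoromethoxy)phenyl for propyl and also stayed within the scatter. Since neither exchange at or around this site moved the read-out beyond the scatter, no step beyond the scatter is expected for the fluoro in place of trifluoromethoxy either, and a number 2.2 percentage points higher from compound 3 to compound 4 (within the scatter) is the estimated step. Compound 4 is therefore expected to give 0%, within a range from -9% to 9%.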

Compound 4, a percentage reported as inhibition, at one concentration (the size of the read-out at that concentration, not a potency): 4.27%
For compound 4 the middle estimate is 4.3 percentage points below the measured one; the range from low to high includes it.
By their numbers in this assay, from the lowest: compounds 2, 3, 4 and 1 (each within the scatter of the next).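

In this assay, replacing trifluoromethoxy (5 heavy atoms) with fluoro (1 heavy atom) on the aromatic carbon para to a large group gives a number 6.5 percentage points higher from compound 3 to compound 4 (within the scatter), so this reduction in the size of the group does not take the read-out beyond the scatter. With a number 2.7 percentage points lower from compound 1 to compound 4 (within the scatter) as well, bromo, trifluoromethoxy and fluoro at this place all lie within the scatter of one another, which adds a third group to the two compared before and gives no order among them. The whole 4-fluorophenyl also cannot be told apart from propyl, with a number 6.5 percentage points higher from compound 2 to compound 4 (within the scatter) being the step, and no evidence is available that bears on these small differences.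

Whether an amine or a carboxylic acid on this same aromatic carbon would also stay within the scatter remains open, since the groups shown here at that place are only halogens and trifluoromethoxy. Also open, as far as these compounds go, is whether these compounds would separate at any concentration other than the one tested, and whether a change elsewhere on the shared core would move the read-out beyond the scatter.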